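Fluoro for hydrogen on two related cores

This account rests on a few compounds, and the source may have more. Where it says the series, first, only, none or still open, it means among the compounds named here.

Compound 1 `Cn1cnc2c(Sc3ccccc3)ncnc21` gives 0% in an assay on isolated protein for inhibition of RAC-alpha serine/threonine-protein kinase (Homo sapiens), tested at 30 uM; on this read-out lower numbers stand for less inhibition and higher numbers for more inhibition at the one concentration tested (going by the name of the read-out). Compound 2 `Cn1cnc2c(Sc3ccc(F)cc3)ncnc21` differs from compound 1 by fluoro in place of hydrogen on an aromatic carbon; in this assay compound 2 gives 0%. The step of no change at the digits printed from compound 1 to compound 2 (within the scatter) shows that this change left the read-out where it stood.

Compound 3 `Clc1ncnc2c1ncn2Cc1ccccc1` is built on another core; the difference between the core of compound 1 and the core of compound 3 is not broken down here. In this assay compound 3 gives 0%, which is level with compound 1 and compound 2 within the scatter, so no order among the three can be drawn from these values.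

Compound 4 `Fc1ccc(Cn2cnc3c(Cl)ncnc32)cc1` has not yet been measured. It differs from compound 3 by fluoro in place of hydrogen on an aromatic carbon. Among the compounds with values here, the place of entry is described in the same words for both pairs, so this is the same change as the one from compound 1 to compound 2, made on a core that differs in a way not counted here.

The step from compound 3 to compound 4 is expected to be no change at the digits printed from compound 3 to compound 4 (within the scatter) in this assay, resting on the earlier step of no change at the digits printed from compound 1 to compound 2 (within the scatter) and on compound 3 sitting at 0%. Compound 4 is therefore estimated to give 0%, with the expected range running from -8% to 10%. Within the data shown here, that this change raised nothing in compound 2 is the only guide available; the measured value will show whether the other core behaves alike.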

Compound 4, a percentage reported as inhibition, at one concentration (the size of the read-out at that concentration, not a potency): 0%
For compound 4 middle estimate and measured number coincide at the digits printed; the range from low to high includes it.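

In this assay the fluoro for hydrogen change on the second core reads no change at the digits printed from compound 3 to compound 4 (within the scatter), and set beside the same change on the first core it gives the same picture: the same change on two cores in this assay, no change at the digits printed (within the scatter) from compound 1 to compound 2 and no change at the digits printed (within the scatter) from compound 3 to compound 4, 0 percentage points apart, within the scatter of two such steps

For these two pairs, then, the replacement carries from the core of compound 1 to the core of compound 3 with the read-out left where it stood. This does not show that the change is neutral in general: compound 1 gives 0% and compound 3 gives 0%, so both steps start from a read-out with no inhibition to lose, and agreement between them says nothing about how the change would carry on a compound with readable inhibition.

Open, on these data alone, is whether any group on these cores gives a read-out different from the one shared by all four compounds, for instance an amine in place of the chloro group of compound 3 and compound 4. Also open, as far as these compounds go, is whether a carboxylic acid or a longer chain on the aromatic ring that takes the fluoro would move the read-out, and whether fluoro would then still leave it unchanged.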